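This account rests on a few compounds, and the source may have more. Where it says the series, first, only, none or still open, it means among the compounds named here.

Measured so far:
compound 1, `COc1cc(OC)cc(-c2cc3ccccc3c(-c3cccc(O)c3)n2)c1`: in a functional assay on HCT-15 cells (Homo sapiens) for cytotoxicity, read by CCK-8 assay and cell counting, with a stated time of 72 h (a lower number here means a stronger inhibitor, a higher number a weaker inhibitor), compound 1 gives 840 nM
compound 2, `COc1cc(OC)cc(-c2cc3ccccc3c(-c3cccc(N)c3)n2)c1`: compound 2 gives 4080 nM
compound 3, `COc1ccc(-c2cc3cc(C)ccc3c(-c3cccc(O)c3)n2)c(C)c1`: compound 3 gives 1750 nM

Compound 1 and compound 2 differ only by amino in place of hydroxy on an aromatic carbon, and this change gave a 4.9-fold higher number from compound 1 to compound 2 (0.69 log units; beyond the scatter). Compound 3 sits on another core; the difference between the core of compound 1 and the core of compound 3 is not broken down here. Compound 4, `COc1ccc(-c2cc3cc(C)ccc3c(-c3cccc(N)c3)n2)c(C)c1`, is not yet measured. It differs from compound 3 by amino in place of hydroxy on an aromatic carbon, the same change as between compound 1 and compound 2, at the same place. Since the step of a 4.9-fold higher number from compound 1 to compound 2 (0.69 log units; beyond the scatter) was beyond the scatter, a step of similar size is expected here, roughly a 4.6-fold higher number from compound 3 to compound 4 (0.66 log units; beyond the scatter), with some allowance for the other core. Compound 4 is therefore expected near 8000 nM, with a range of 3500 nM to 20000 nM.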

Compound 4, half-maximal inhibitory concentration: 2770 nM
Compound 4: middle estimate off by 2.9-fold (0.46 log units), on the high side; measured number outside the range, below it.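

In this assay, amino in place of hydroxy on an aromatic carbon gave a 1.6-fold higher number from compound 3 to compound 4 (0.20 log units; within the scatter), a step that does not stand out from the usual scatter. The size of the step did not carry over from one core to the other: the same change on two cores in this assay, a 4.9-fold higher number (0.69 log units; beyond the scatter) from compound 1 to compound 2 and a 1.6-fold higher number (0.20 log units; within the scatter) from compound 3 to compound 4, 3.1-fold (0.49 log units) apart, beyond the scatter of two such steps. This shows that, across these two pairs, the step from 3-hydroxyphenyl to 3-aminophenyl differs with the core, but it does not show which difference between the cores accounts for this or how the change would read on a further core.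

Still open, as far as these compounds go, is how a carboxylic acid or an amide at this place would read on either core. Also open, from the compounds shown here alone, is whether a core carrying only some of the differences between these two cores would give a step nearer the larger or the smaller one.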